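Swapping the halogen pattern on the amide-bound ring

A few compounds are considered here, and "the series" means these few. Any claim that something is new, unique, unknown or untested is made for them only; others in the source may bear on it.

Measured so far:
compound 1 `O=C(CSc1nc(Nc2ccccc2)c2ccccc2n1)Nc1ccccc1Cl`: 24800 nM
compound 2 `O=C(CSc1nc(Nc2ccccc2)c2ccccc2n1)Nc1ccc(Cl)cc1Cl`: 12300 nM

Both compounds share one core and differ only in the ring attached to the amide nitrogen. In a functional assay on MGC-803 cells (Homo sapiens) for inhibition, read by MTT assay, with a stated time of 72 h (a higher number here means a weaker inhibitor, a lower number a stronger inhibitor), compound 1 gives 24800 nM, the highest of the two numbers shown. Its nearest neighbour is compound 2, which in this assay gives 12300 nM; the step between them, a 2.0-fold lower number from compound 1 to compound 2 (0.30 log units; within the scatter), comes from chloro in place of hydrogen on an aromatic carbon and does not rise above the usual scatter.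

The unmeasured compound 3 `O=C(CSc1nc(Nc2ccccc2)c2ccccc2n1)Nc1ccc(F)c(Cl)c1` differs from compound 1 in one place: 3-chloro-4-fluorophenyl in place of 2-chlorophenyl on an amide-type nitrogen. For the measured compounds named here, the only measured step that speaks to this kind of change is the one from compound 1 to compound 2, and it was small. Adding a halogen to the ring on the amide nitrogen has so far not moved the number beyond the scatter, so no clear step is expected for compound 3 either. The estimate for compound 3 in this assay is therefore 16000 nM, with a range from 6000 nM to 45000 nM, which amounts to an expected step of a 1.6-fold lower number from compound 1 to compound 3 (0.19 log units; within the scatter).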

Compound 3, half-maximal inhibitory concentration: 20900 nM
For compound 3 the middle estimate is 1.3-fold (0.12 log units) below the measured one, within the range that was stated.
By their numbers in this assay, from the lowest: compounds 2, 3 and 1 (each within the scatter of the next).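

The step from compound 1 to compound 2 only added a chloro to the ring, whereas compound 3 brings in fluorine and a different halogen pattern. In this assay, the change to 3-chloro-4-fluorophenyl gives a 1.2-fold lower number from compound 1 to compound 3 (0.07 log units; within the scatter) and the change from 2,4-dichlorophenyl to the same group gives a 1.7-fold higher number from compound 2 to compound 3 (0.23 log units; within the scatter). All three steps among these compounds therefore lie within the scatter, so the three halogen patterns on the ring at the amide-type nitrogen cannot be told apart here, and no evidence is available to explain this result.

Every ring shown carries only chlorine or fluorine, so the compounds leave open whether a plain phenyl ring, or a ring bearing an amine, a carboxylic acid or a methoxy group, would give a step beyond the scatter. They also leave open what a longer chain between the amide nitrogen and the ring would do, and whether changes elsewhere on the shared core would matter more than changes at this position.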